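Swapping 4-fluorophenyl for 2-vinylphenyl on the shared core

The source may report more compounds than this note shows. Statements on the series, on what has been measured and on what is new or still open speak of the compounds shown alone.

Three measured entries share one core: compound 1 `COC1=C(C)C(=O)/C(=C(O)/C=C/c2ccc(O)cc2)C(=O)C1(C)C`, compound 2 `COC1=C(C)C(=O)/C(=C(O)/C=C/c2ccc(F)cc2)C(=O)C1(C)C` and compound 3 `COC1=C(C)C(=O)/C(=C(O)/C=C/c2c(C)cc(C)cc2C)C(=O)C1(C)C`. In a functional assay on HUVEC cells (Homo sapiens) for cytotoxicity (a higher number here means that more compound is needed for the effect, a lower number that less compound is needed), compound 1 gives 3.8 ug/mL and compound 2 gives 2 ug/mL. The entry for compound 3 reads "not determined" (no result reported), so it offers no number for comparison. Compound 2 therefore has a single numerical neighbour, compound 1, and the two lie within the scatter of each other.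

The next structure is compound 4 `C=Cc1ccccc1/C=C/C(O)=C1/C(=O)C(C)=C(OC)C(C)(C)C1=O`, with this change: 2-vinylphenyl in place of 4-fluorophenyl on a double-bonded chain carbon bound to a double-bonded chain carbon. Among the measured compounds shown here, only one measured step bears on it, an exchange of a group on the aromatic ring: a 1.9-fold lower number from compound 1 to compound 2 (0.28 log units; within the scatter), which is within the scatter. For the measured compounds named here, that exchange involves different groups, and no measured compound carries a 2-vinylphenyl group. No step beyond the scatter is therefore expected in this assay, and the data indicate no firm direction. The expected step is a 1.3-fold higher number from compound 2 to compound 4 (0.10 log units; within the scatter). For compound 4 the estimated value is 2.5 ug/mL, with an expected range from 1 ug/mL to 7 ug/mL.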

Compound 4, concentration for half-maximal effect: 1.1 ug/mL
Estimate against measurement, compound 4: 2.3-fold (0.36 log units) above; the measured number falls inside the stated range.
By their numbers in this assay, from the lowest: compounds 4, 2 and 1 (each within the scatter of the next, the first and the last beyond it).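

At the place on a double-bonded chain carbon bound to a double-bonded chain carbon, replacing 4-fluorophenyl with 2-vinylphenyl gives a 1.8-fold lower number from compound 2 to compound 4 (0.26 log units; within the scatter) in this assay, so these two groups are not separated. Replacing 4-hydroxyphenyl with 2-vinylphenyl gives a 3.5-fold lower number from compound 1 to compound 4 (0.54 log units; beyond the scatter) and is the only step shown beyond the scatter, which shows that the group at this place can shift the read-out, if only modestly. No measurement shown here offers an explanation for this step.

The compounds shown leave open whether the vinyl group itself matters, as a 2-ethylphenyl group would test. They also leave open how this assay responds to an amine or a carboxylic acid on the phenyl ring at this place.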